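The compounds below may be only part of what the source reports. "The series", "measured", "known", "first", "only" and "open" are said of these compounds alone.

Working notes on the series, read in a functional assay on JAR cells (Homo sapiens) for inhibition, read by MTT assay, with a stated time of 72 h; on this read-out lower numbers stand for stronger inhibition and higher numbers for weaker inhibition. Three compounds share one core and differ only in the group on the double-bonded chain carbon. Compound 1 `CCOC(=O)C1=C(Nc2ccccc2)S/C(=C\c2ccc(O)c(O)c2)C1=O` gives 6100 nM, compound 2 `CCOC(=O)C1=C(Nc2ccccc2)S/C(=C\c2cccc(C(=O)O)c2)C1=O` gives 11700 nM and compound 3 `CCOC(=O)C1=C(Nc2ccccc2)S/C(=C\c2ccc[nH]2)C1=O` gives 9500 nM. Compound 3 is not separated from either of the other two, and all three values lie within the scatter of one another: a 1.9-fold higher number from compound 1 to compound 2 (0.28 log units; within the scatter), a 1.6-fold higher number from compound 1 to compound 3 (0.19 log units; within the scatter) and a 1.2-fold lower number from compound 2 to compound 3 (0.09 log units; within the scatter).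

Compound 4 `CCOC(=O)C1=C(Nc2ccc(F)cc2)S/C(=C\c2ccc[nH]2)C1=O` keeps the 1H-pyrrol-2-yl group of compound 3 and alters the anilino group, phenyl becoming 4-fluorophenyl: fluoro in place of hydrogen on an aromatic carbon. The fluoro group sits para to a large group. Within the data shown here, no measured step touches this place, since all three exchange the group on the double-bonded chain carbon. Among the measured compounds shown here, they therefore give no direct reading of the new change, and show only that exchanges elsewhere on the core stayed within the scatter.

With nothing to set a direction or size, no step beyond the scatter is expected in this assay, and the anchor is compound 3 at 9500 nM. The estimated step is a 1.1-fold lower number from compound 3 to compound 4 (0.02 log units; within the scatter), which is expected to stay within the scatter. For compound 4 the expected value is 9000 nM, with an estimated range of 4500 nM to 18000 nM.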

Compound 4, half-maximal inhibitory concentration: 15900 nM
The estimate for compound 4 lay 1.8-fold (0.25 log units) below the measured number, within the range that was stated.
By their numbers in this assay, from the lowest: compounds 1, 3, 2 and 4 (each within the scatter of the next, the first and the last beyond it).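

In this assay, among these compounds, the only exchange at the anilino group gives a 1.7-fold higher number from compound 3 to compound 4 (0.22 log units; within the scatter), so fluoro in place of hydrogen on an aromatic carbon, para to a large group, is not separated from the hydrogen of compound 3. The anilino group thus joins the double-bonded chain carbon as a place where an exchange among the compounds shown stays within the scatter, although this reading rests on a single pair that carries the 1H-pyrrol-2-yl group. Nothing available bears on the origin of this result, and no explanation can be attached to the fluoro group.

Going by these compounds, whether the same exchange would read alike with 3,4-dihydroxyphenyl or 3-carboxyphenyl on the double-bonded chain carbon remains open, as compound 1 and compound 2 both carry phenyl on the anilino nitrogen. On these data alone, it is also open whether a methoxy group, an amine or a carboxylic acid in place of the fluoro group would give a step beyond the scatter, so the tolerance of this position is defined by one exchange only.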